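A Bigger Swap on a Shared Core

The source may hold more compounds than are shown below. What is called first, only, known or untested is meant among the compounds shown, and "the series" means these compounds.

In a functional assay (trachea) with Cavia porcellus as the target (a higher number here means a weaker inhibitor, a lower number a stronger inhibitor), compound 1 (`CCCCn1nc(-c2cccnc2)c2ccccc2c1=O`) gives 2290 nM and compound 2 (`O=c1c2ccccc2c(-c2cccnc2)nn1CCO`) gives 4570 nM on the same core. With only these two numbers to compare, compound 2 stands within the scatter of compound 1, so the two cannot be told apart.

The next compound is compound 3 (`O=C(O)c1ccc(Cn2nc(-c3cccnc3)c3ccccc3c2=O)cc1`). The change is 4-carboxyphenyl in place of hydroxymethyl on a saturated chain carbon bound to an aromatic nitrogen and it amounts to 4-carboxyphenyl in place of hydroxymethyl on a saturated chain carbon bound to an aromatic nitrogen.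

Within the data shown here, only one measured step bears on this swap, and it also alters the chain on that aromatic nitrogen. It is a 2.0-fold higher number from compound 1 to compound 2 (0.30 log units; within the scatter) and so gives no sign that this chain matters much in this assay for these two compounds. Among the measured compounds shown here, no measured compound carries a 4-carboxyphenyl, so this single step is a weak guide. No shift beyond the scatter is therefore expected, though with wide uncertainty. The expected change is a 1.3-fold lower number from compound 2 to compound 3 (0.12 log units; within the scatter) in this estimate. For compound 3 the estimated value is 3500 nM with 800 nM to 15000 nM as the expected range.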

Compound 3, half-maximal inhibitory concentration: 17000 nM
The estimate for compound 3 lay 4.9-fold (0.69 log units) below the measured number; measured number outside the range, above it.
By their numbers in this assay, from the lowest: compounds 1 and 2 (each within the scatter of the next); then compound 3.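

In this assay, the chain carbon bound to the aromatic nitrogen proves sensitive to what it carries: a 3.7-fold higher number from compound 2 to compound 3 (0.57 log units; beyond the scatter), and a 7.4-fold higher number from compound 1 to compound 3 (0.87 log units; beyond the scatter). Both steps lie beyond the scatter and point the same way, towards weaker inhibition, whereas the step between the two simple chains of compound 1 and compound 2 stayed within it. So the two simple chains cannot be told apart in this assay, but 4-carboxyphenyl at the same place gives a clearly weaker inhibitor than either, and the data at hand offer no explanation for this loss.

The swap to compound 3 brings in a six-membered aromatic ring of carbon only and a carboxylic acid together, so the compounds shown cannot say which of the two accounts for the loss, and a plain phenyl group at this place, with no carboxylic acid, would separate them. Also open, from the compounds shown here alone, is whether any other group here, such as an amine or a longer chain, would lower the number below that of compound 1 rather than raise it.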